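This account rests on a few compounds, and the source may have more. Where it says the series, first, only, none or still open, it means among the compounds named here.

Working notes on the series. Compound 1 `Cc1ccc(S(=O)(=O)N[C@@H](CC(=O)NC(C)(C)C)C(=O)NCCNC(=O)c2cc(C)ccc2F)cc1`, compound 2 `Cc1ccc(S(=O)(=O)N[C@@H](CC(=O)NC(C)(C)C)C(=O)NCCNC(=O)c2cc(Cl)ccc2Cl)cc1` and compound 3 `Cc1ccc(S(=O)(=O)N[C@@H](CC(=O)NC(C)(C)C)C(=O)NCCNC(=O)c2ccccc2O)cc1` share one core and have been measured in an ADME assay on Karpas-1106P cells (Homo sapiens) for cytotoxicity; on this read-out lower numbers stand for an effect already at smaller amounts and higher numbers for an effect only at larger amounts of compound. In this assay compound 1 gives > 11100 nM, which is a limit of the assay and not a number. In this assay compound 2 gives > 11100 nM, again a limit. In this assay compound 3 gives > 11100 nM, also a limit. Compound 2 thus stands at the limit of > 11100 nM in this assay, at which 3 of the 3 values shown sit, alongside the other two values. The steps a step that the two limits leave unreadable from compound 1 to compound 2, a step that the two limits leave unreadable from compound 1 to compound 3 and a step that the two limits leave unreadable from compound 2 to compound 3 are all of unreadable size, since both ends sit at a limit. Compound 4 `Cc1ccc(S(=O)(=O)N[C@@H](CC(=O)NC(C)(C)C)C(=O)NCCNC(=O)c2cccc(C#N)c2)cc1` is not yet measured; its difference from compound 2 is 3-cyanophenyl in place of 2,5-dichlorophenyl on a carbonyl carbon. Because every measured exchange on the carbonyl carbon stays at the limit of > 11100 nM in this assay, at which 3 of the 3 values shown sit, no step beyond the scatter in this assay is expected in either direction. The step is estimated as a step that the limit leaves unreadable from compound 2 to compound 4. Compound 4 is expected in this assay at 20000 nM, between 11100 nM and 60000 nM, most probably reported again only as a limit.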

Compound 4, half-maximal effective concentration: > 11100 nM
Compound 4 gave a limit, no number; the forecaster's own chance of this, stated with the estimate: 85%; the middle value does not contradict the limit.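

No new step can be read between compound 4 and compound 1, compound 2 or compound 3 in this assay, since each value is a limit and not a number: the limit of > 11100 nM in this assay, at which 4 of the 4 values shown sit.

The compounds shown leave open whether any exchange on the carbonyl carbon changes the read-out in this assay, and at what concentration any of these compounds would show an effect.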